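The source may report more compounds than this note shows. Statements on the series, on what has been measured and on what is new or still open speak of the compounds shown alone.

- compound 1 `C=C(c1ccc(OC)cc1NC(=O)CO)c1ccc(OC)c2c1OC(C)(C)C=C2`: 40 nM
- compound 2 `C=C(c1ccc(OC)cc1NC(=O)CN)c1ccc(OC)c2c1OC(C)(C)C=C2`: 50 nM
- compound 3 `C=C(c1ccc(OC)cc1NC(=O)CNCC)c1ccc(OC)c2c1OC(C)(C)C=C2`: 970 nM

All three values come from a functional assay on A549 cells (Homo sapiens) for antiproliferative activity, read by MTT assay, with a stated time of 48 h; a lower number here means a stronger inhibitor, a higher number a weaker inhibitor. Compound 3 gives the highest number of the three, so it is the weakest inhibitor in this set. Compound 4 `C=C(c1ccc(OC)cc1NC(=O)CN(C)C)c1ccc(OC)c2c1OC(C)(C)C=C2` has not yet been measured. It carries dimethylamino in place of ethylamino on a saturated chain carbon bound to a carbonyl carbon. The two compounds have the same atoms, joined differently.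

Within the data shown here, no measured step makes this exact swap, so the nearest steps must serve as a guide. Changing hydroxy to amino gave a 1.3-fold higher number from compound 1 to compound 2 (0.10 log units; within the scatter). Adding ethyl to the amine nitrogen gave a 19-fold higher number from compound 2 to compound 3 (1.29 log units; beyond the scatter), and the full change from hydroxy to ethylamino gave a 24-fold higher number from compound 1 to compound 3 (1.38 log units; beyond the scatter). The nitrogen in compound 4 stays substituted, as in compound 3, so a full return to the level of compound 2 at 50 nM seems unlikely. A partial recovery is still plausible, though three compounds give only weak support.

The expected change is a 2.8-fold lower number from compound 3 to compound 4 (0.44 log units; beyond the scatter), towards a lower number. The estimated value for compound 4 is 350 nM, with an expected range of 70 nM to 1400 nM.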

Compound 4, half-maximal inhibitory concentration: 270 nM
Compound 4: the middle estimate sits 1.3-fold (0.11 log units) above what was measured; the range from low to high includes it.
By their numbers in this assay, from the lowest: compounds 1 and 2 (each within the scatter of the next); then compound 4; then compound 3.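

In this assay, rearranging the same atoms from ethylamino to dimethylamino gives a 3.6-fold lower number from compound 3 to compound 4 (0.56 log units; beyond the scatter), so how the two carbons sit on this nitrogen matters, not just how many there are. Substitution on the nitrogen still carries a cost, as dimethylamino in place of amino gives a 5.4-fold higher number from compound 2 to compound 4 (0.73 log units; beyond the scatter), and dimethylamino in place of hydroxy gives a 6.8-fold higher number from compound 1 to compound 4 (0.83 log units; beyond the scatter). Compound 3 keeps a hydrogen-bond donor in this group and compound 4 has none, yet compound 4 gives the lower number, so having a donor here does not by itself decide the result.

Going by these compounds, how diethylamino, a ring amine such as morpholine, or a carboxylic acid would behave at this position remains open. Nothing shown here explains why these two groups of the same atoms differ.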